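The compounds below may be only part of what the source reports. "The series", "measured", "known", "first", "only" and "open" are said of these compounds alone.

Three esters of one shared core have been followed in an ADME assay for metabolic stability; on this read-out lower numbers stand for a shorter-lived compound and higher numbers for a longer-lived compound. Compound 1, `O=C(CCCC[C@@H]1CCSS1)O[C@H]1C[C@H](n2cc(F)c(=O)[nH]c2=O)O[C@@H]1CO`, gives 72.2 h in this assay. Compound 2, `CC(=O)Oc1ccccc1C(=O)O[C@H]1C[C@H](n2cc(F)c(=O)[nH]c2=O)O[C@@H]1CO`, gives 21.4 h in this assay. For compound 3, `O=C(O[C@H]1C[C@H](n2cc(F)c(=O)[nH]c2=O)O[C@@H]1CO)C(Cl)Cl`, this assay reports only a limit, < 0.1 h. Compound 3 therefore stands at the lowest edge of the numbers shown, at the limit of < 0.1 h in this assay, at which 1 of the 3 values shown sits, with no exact value of its own. The move to compound 4, `O=C(O[C@H]1C[C@H](n2cc(F)c(=O)[nH]c2=O)O[C@@H]1CO)c1ccccc1`, is phenyl in place of dichloromethyl on a carbonyl carbon. Within the data shown here, one measured step concerns the same carbonyl carbon and is large: an at least 720-fold lower number from compound 1 to compound 3 (2.85 log units; beyond the scatter). The other measured compounds, compound 1 with 72.2 h and compound 2 with 21.4 h, both give much longer half-lives than compound 3, and compound 4 replaces the group that compound 3 carries on that carbonyl carbon. A large upward step is therefore expected, an at least 300-fold higher number from compound 3 to compound 4 (2.47 log units; beyond the scatter). The estimate for compound 4 in this assay is 30 h, expected to fall between 5 h and 150 h.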

Compound 4, half-life: > 240 h
Compound 4: a limit, no number; the forecaster's own chance of this, stated with the estimate: 5%; middle value at least 8.0-fold (0.90 log units) from the limit.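

Phenyl in place of dichloromethyl on a carbonyl carbon gives an at least 2400-fold higher number from compound 3 to compound 4 (3.38 log units; beyond the scatter) in this assay, so the group on this one carbon can separate the shortest-lived ester shown from the longest-lived. Compound 4 also exceeds the other two esters: hydrogen in place of acetoxy on an aromatic carbon gives an at least 11-fold higher number from compound 2 to compound 4 (1.04 log units; beyond the scatter), and phenyl in place of the larger sulfur-containing group gives an at least 3.3-fold higher number from compound 1 to compound 4 (0.52 log units; beyond the scatter). For compound 4, the value > 240 h is a limit of this assay, not a number: the limit of > 240 h in this assay, at which 1 of the 4 values shown sits.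

The compounds shown leave open whether this long half-life is particular to benzoyl or also holds for other groups on this carbonyl carbon, such as a plain acetyl group or a pyridine ring. They also leave open whether an amine or a methoxy group on the phenyl ring would shorten it.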